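The source may report more compounds than this note shows. Statements on the series, on what has been measured and on what is new or still open speak of the compounds shown alone.

Measured in a functional assay, tested at 200 ug/mL; a higher number here means a stronger effect of the compound at the concentration tested, a lower number a weaker effect:
compound 1 `Cc1ccccc1C1C(C#N)=C(N)OC(c2c[nH]c3ccccc23)=C1C#N` gives 21.4%
compound 2 `Cc1ccc(C2C(C#N)=C(N)OC(c3c[nH]c4ccccc34)=C2C#N)cc1` gives 6.2%
compound 3 `N#CC1=C(N)OC(c2c[nH]c3ccccc23)=C(C#N)C1c1ccccc1Cl` gives 14.5%

Compound 3 sits between the other two without separating from either: the step of a number 6.9 percentage points lower from compound 1 to compound 3 (within the scatter) and the step of a number 8.3 percentage points higher from compound 2 to compound 3 (within the scatter) both lie within the scatter. Among the measured compounds shown here, the only step beyond the scatter is a number 15.2 percentage points lower from compound 1 to compound 2 (beyond the scatter). Compound 4 `N#CC1=C(N)OC(c2c[nH]c3ccccc23)=C(C#N)C1c1ccccc1` differs from compound 3 by hydrogen in place of chloro on an aromatic carbon. For the measured compounds named here, the measured step that bears on this is the swap of one group for another at the same aromatic carbon, a number 6.9 percentage points lower from compound 1 to compound 3 (within the scatter), which stayed within the scatter; no measured step removes that group altogether. Compound 4 is therefore expected to move little, a number 3.5 percentage points lower from compound 3 to compound 4 (within the scatter), a step within the scatter. The estimate for compound 4 is 11%, with a range from 3% to 22%.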

Compound 4, a percentage reported as activity, at one concentration (the size of the read-out at that concentration, not a potency): 24.5%
Estimate against measurement, compound 4: 13.5 percentage points below; the whole stated range lies below it.
By their numbers in this assay, from the lowest: compounds 2, 3, 1 and 4 (each within the scatter of the next, the first and the last beyond it).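

In this assay, the step of a number 10 percentage points higher from compound 3 to compound 4 (within the scatter) and the step of a number 3.1 percentage points higher from compound 1 to compound 4 (within the scatter) show that hydrogen, chloro and methyl on this aromatic carbon cannot be told apart. Phenyl therefore joins 2-chlorophenyl and 2-methylphenyl as one unresolved group at this position. The step of a number 18.3 percentage points higher from compound 2 to compound 4 (beyond the scatter) adds a second separation from the 4-methylphenyl compound, although compound 2 and compound 3 remain within the scatter of each other.

No available measurement explains these steps. Going by these compounds, whether a methoxy group or an amine on this aromatic carbon would also stay within the scatter remains open.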